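Removing the Fluoro Substituent from a Bromophenyl Urea Antagonist

This account rests on a few compounds, and the source may have more. Where it says the series, first, only, none or still open, it means among the compounds named here.

Compound 1, `Cc1cccc2c1CCN2CCNC(=O)Nc1ccccc1Br`, gives 7.4 in a functional assay for antagonist activity at transient receptor potential cation channel subfamily V member 1 (Rattus norvegicus), read by FLIPR; a higher number here means a more potent compound, by a factor of ten per unit of this negative logarithm, a lower number a less potent compound.
Compound 2, `Cc1ccc2c(c1)CCN2CCNC(=O)Nc1ccccc1Br`, gives 7.3 in this assay.
Compound 3, `O=C(NCCN1CCc2c(F)cccc21)Nc1ccccc1Br`, gives 7.4 in this assay.

Compound 3 stands level with compound 1 among these three numbers, and compound 2 lies a little lower, a gap that falls within the scatter. Going by the values given here, the only single-point step measured so far, no change at the digits printed from compound 1 to compound 3 (within the scatter), shows that exchanging the methyl of compound 1 for the fluoro of compound 3 left the read-out unchanged. Compound 4, `O=C(NCCN1CCc2ccccc21)Nc1ccccc1Br`, takes the next step away: hydrogen in place of fluoro on an aromatic carbon. Among the compounds with values here, no measured step removes a substituent entirely, so the expectation rests on the observation that methyl at two different positions and fluoro all give one level in this assay. On that basis the step of a number 0.10 log units lower from compound 3 to compound 4 (within the scatter) is estimated to stay within the scatter. Compound 4 is therefore expected to give about 7.3 in this assay, with a likely range from 6.8 to 7.8.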

Compound 4, negative logarithm of the antagonist equilibrium constant: 6.8
The estimate for compound 4 lay 0.50 log units above the measured number; the measured number falls inside the stated range.
By their numbers in this assay, from the lowest: compound 4; then compounds 2, 1 and 3 (each within the scatter of the next).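

In this assay, hydrogen in place of fluoro on this aromatic carbon gives a number 0.60 log units lower from compound 3 to compound 4 (beyond the scatter), and hydrogen in place of methyl gives a number 0.60 log units lower from compound 1 to compound 4 (beyond the scatter) and a number 0.50 log units lower from compound 2 to compound 4 (beyond the scatter). The earlier compounds shown here showed only that methyl and fluoro were interchangeable here, and that moving the methyl to the other ring carbon of compound 2 left the number within the scatter. Compound 4 adds what they could not show: among these four compounds, the shared level depends on a substituent being on the six-membered aromatic ring at all, and the unsubstituted ring alone falls beyond the scatter, though only modestly.

Going by these compounds, whether a larger group, such as methoxy, trifluoromethyl or an amine, would hold that level on this carbon remains open. What lies behind the drop also stays open, as nothing available here bears on it.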